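Anilino to 4-bromophenoxy on the triazole arm

The source may hold more compounds than are shown below. What is called first, only, known or untested is meant among the compounds shown, and "the series" means these compounds.

Compound 1 `O=c1cc(-n2cc(CNc3ccccc3)nn2)c2cc(Br)ccc2o1` stands only at a limit. In a functional assay on MCF7 cells (Homo sapiens) for antiproliferative activity, read by MTT assay, with a stated time of 48 h (on this read-out higher numbers stand for weaker inhibition and lower numbers for stronger inhibition), compound 1 gives > 50000 nM, which is a limit of the assay and not a number. Compound 2 `O=c1cc(-n2cc(CSc3ccccc3)nn2)c2cc(Br)ccc2o1` gives 36800 nM in this assay, and compound 3 `Nc1ccc(OCc2cn(-c3cc(=O)oc4ccc(Br)cc34)nn2)cc1` gives 2040 nM. The step of an at least 1.3-fold lower number from compound 1 to compound 2 (0.13 log units; that floor lies within the scatter) lies within the scatter, whereas the steps of an at least 24-fold lower number from compound 1 to compound 3 (1.38 log units; beyond the scatter) and an 18-fold lower number from compound 2 to compound 3 (1.26 log units; beyond the scatter) are both large. The unmeasured compound 4 `O=c1cc(-n2cc(COc3ccc(Br)cc3)nn2)c2cc(Br)ccc2o1` differs from compound 1 in that (4-bromophenoxy in place of anilino on a saturated chain carbon bound to an aromatic carbon). This shares the phenoxy link of compound 3 while carrying bromine instead of the amino group, so a lowering beyond the scatter is expected but of uncertain size. The expected step is an at least 5.5-fold lower number from compound 1 to compound 4 (0.74 log units; beyond the scatter). Compound 4 is therefore estimated at 9000 nM, ranging from 2000 nM to 45000 nM.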

Compound 4, half-maximal inhibitory concentration: 1920 nM
For compound 4 the middle estimate is 4.7-fold (0.67 log units) above the measured one; the whole stated range lies above it.
By their numbers in this assay, from the lowest: compounds 4 and 3 (each within the scatter of the next); then compound 2. At a limit, above all of these: compound 1.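

With 4-bromophenoxy in place of anilino, this assay shows an at least 26-fold lower number from compound 1 to compound 4 (1.41 log units; beyond the scatter), a floor and not a full size. Compound 1 stands at a limit of the assay, not a number: the limit of > 50000 nM in this assay, at which 1 of the 4 values shown sits. Bromo in place of amino leaves no readable difference, a 1.1-fold lower number from compound 3 to compound 4 (0.03 log units; within the scatter), whereas 4-bromophenoxy in place of phenylsulfanyl gives a 19-fold lower number from compound 2 to compound 4 (1.28 log units; beyond the scatter), so the large step seen with 4-aminophenoxy does not depend on the amino group.

As far as these compounds go, it remains open whether plain phenoxy, or a methoxy group or carboxylic acid in place of the bromo, would read the same. From the compounds shown here alone, the effect of a longer chain also remains open.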